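The source may report more compounds than this note shows. Statements on the series, on what has been measured and on what is new or still open speak of the compounds shown alone.

Working notes on the series. Compound 1 `CCCCOc1ccc2c(Cl)ccnc2c1` gives 4130 nM in a functional assay on SK-OV-3 cells (Homo sapiens) for cytotoxicity, read by MTT assay, with a stated time of 48 h (on this read-out higher numbers stand for weaker inhibition and lower numbers for stronger inhibition), the lowest of the two numbers in hand; compound 2 `CCOc1ccc2c(NCCN(C)C)ccnc2c1` gives 4620 nM in this assay, and the two values lie within the scatter of each other, so no order between them is claimed. Among the compounds with values here, no step between measured compounds that differ in one place is available, and compound 1 and compound 2 differ in more than one place.

Compound 3 `Clc1ccnc2cc(OCCc3ccccc3)ccc12` has not yet been measured in this assay. It differs from compound 1 by phenyl in place of ethyl on a saturated chain carbon, two bonds along the chain from an oxygen on an aromatic ring. With no measured step of this kind in the series, the expected step is a 1.4-fold lower number from compound 1 to compound 3 (0.14 log units; within the scatter), a shift toward a lower number that may well stay within the scatter. Compound 3 is therefore expected to give about 3000 nM in this assay, within a range from 1000 nM to 9000 nM.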

Compound 3, half-maximal inhibitory concentration: 2010 nM
For compound 3 the middle estimate is 1.5-fold (0.17 log units) above the measured one; the range from low to high includes it.
By their numbers in this assay, from the lowest: compound 3; then compounds 1 and 2 (each within the scatter of the next).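

In this assay, phenyl in place of ethyl on a saturated chain carbon, two bonds along the chain from an oxygen on an aromatic ring, gives a 2.1-fold lower number from compound 1 to compound 3 (0.31 log units; beyond the scatter), the first single-place step readable in the series. This position therefore accepts the six-carbon aromatic ring in place of the two-carbon ethyl without a move toward weaker inhibition, and the end of this chain is a place where the number can shift. No measurement on hand gives a reason for the shift.

The compounds shown leave open whether the aromatic ring itself matters or only the added carbons, which a cyclohexyl group at the same carbon would separate. They also leave open how an amine or a carboxylic acid would read there.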